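Aryl swap on the amine-bound chain carbon

A few compounds are considered here, and "the series" means these few. Any claim that something is new, unique, unknown or untested is made for them only; others in the source may bear on it.

Compound 3 `Cc1ccc(CN(C)CCCCn2c(=O)oc3ccccc32)c(C)c1` gives 239 nM in an assay on membranes from liver for displacement of a labelled ligand from Sigma non-opioid intracellular receptor 1 (Rattus norvegicus), read by scintillation counting (on this read-out lower numbers stand for stronger inhibition and higher numbers for weaker inhibition), the highest of the three numbers in hand. Compound 1 `COc1ccc(CN(C)C(C)CCn2c(=O)oc3ccccc32)cc1` gives 21 nM in this assay, and compound 2 `COc1ccc(CN(C)CCCn2c(=O)oc3ccccc32)cc1` gives 83 nM. Among the compounds with values here, the single one-point step available, a 4.0-fold higher number from compound 1 to compound 2 (0.60 log units; beyond the scatter), alters the chain and leaves the aryl group untouched, so it does not bear on the present change. Compound 4 `CN(CCCCn1c(=O)oc2ccccc21)Cc1cccc(Cl)c1` differs from compound 3 by 3-chlorophenyl in place of 2,4-dimethylphenyl on a saturated chain carbon bound to an amine nitrogen. Within the data shown here, no measured pair varies the aryl group alone, and nothing in hand indicates the size or direction of such a change. For compound 4 the step of a 1.2-fold lower number from compound 3 to compound 4 (0.08 log units; within the scatter) is therefore expected, within the scatter, with broad uncertainty. The estimated value of compound 4 in this assay is 200 nM, ranging from 60 nM to 700 nM.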

Compound 4, inhibition constant: 302 nM
Compound 4: middle estimate off by 1.5-fold (0.18 log units), on the low side; measured number inside the range.
By their numbers in this assay, from the lowest: compound 1; then compound 2; then compounds 3 and 4 (each within the scatter of the next).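

In this assay, within the data shown here, the first comparison that varies the aryl group alone reads a 1.3-fold higher number from compound 3 to compound 4 (0.10 log units; within the scatter) and so does not separate 3-chlorophenyl from 2,4-dimethylphenyl on a saturated chain carbon bound to an amine nitrogen. On the chain shared by these two compounds, this swap therefore leaves the number inside the usual scatter. No supporting data bear on why the two groups read alike.

Open, from the compounds shown here alone, is whether a pyridine ring or a carboxylic acid-bearing phenyl in this place would read alike. Also open, going by these compounds, is whether 3-chlorophenyl and 2,4-dimethylphenyl would stay level on the chain of compound 2.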